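Adding a second trifluoromethyl to compound 2

The compounds below may be only part of what the source reports. "The series", "measured", "known", "first", "only" and "open" are said of these compounds alone.

In a functional assay on PBMC cells (Homo sapiens) for inhibition, read by HTRF, with stated times of 15 min and 24 h (a lower number here means a stronger inhibitor, a higher number a weaker inhibitor), compound 1 `O=C(Nc1ccc2c(c1)B(O)OC2)c1ccccc1` gives > 100000 nM, which is a limit of the assay. Compound 2 `O=C(Nc1ccc2c(c1)B(O)OC2)c1cccc(C(F)(F)F)c1` gives > 10000 nM, also a limit, so its standing rests on no numerical value.

Compound 3 `O=C(Nc1ccc2c(c1)B(O)OC2)c1cc(C(F)(F)F)ccc1C(F)(F)F` keeps the shared core and takes a further trifluoromethyl in place of hydrogen on an aromatic carbon, ortho to a large group and para to a trifluoromethyl group: trifluoromethyl in place of hydrogen on an aromatic carbon.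

Among the compounds with values here, the only measured step of this kind is a step that the two limits leave unreadable from compound 1 to compound 2. It involves the same exchange, but its size cannot be read, so it gives no firm guide. A move towards stronger inhibition in this assay is expected only tentatively, and another limit remains quite possible.

The estimated change is an at least 2.0-fold lower number from compound 2 to compound 3 (0.30 log units; that floor lies within the scatter). For compound 3 the expected value is 5000 nM, with an estimated range of 500 nM to 30000 nM.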

Compound 3, half-maximal inhibitory concentration: 3000 nM
Estimate against measurement, compound 3: 1.7-fold (0.22 log units) above; measured number inside the range.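

In this assay, within the data shown here, compound 3 is the first compound here to give a number rather than a limit, so trifluoromethyl on this aromatic carbon, ortho to a large group and para to a trifluoromethyl group, gives the first readable step: an at least 3.3-fold lower number from compound 2 to compound 3 (0.52 log units; beyond the scatter). Going by these compounds, that step is a floor and not a full size, and the real gap may be larger, because one end of it is a limit: the limit of > 10000 nM in this assay, at which 1 of the 3 values shown sits. The step from compound 1 to compound 2 cannot be read, so the share of the first trifluoromethyl in this result stays unknown.

Open, on these data alone, is whether trifluoromethyl at this position would give a similar step without the first trifluoromethyl of compound 2. Also open, as far as these compounds go, is whether a chlorine atom, a nitrile or a methoxy group on the same carbon would do the same.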